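A few compounds are considered here, and "the series" means these few. Any claim that something is new, unique, unknown or untested is made for them only; others in the source may bear on it.

Compound 1 `N[C@@H](COP(=O)(O)OCCCOC(=O)CCc1ccccc1OCc1cccc(Oc2ccccc2)c1)C(=O)O` and compound 2 `N[C@@H](COP(=O)(O)OCCCOC(=O)CCc1ccccc1OCc1cccc(Oc2ccc(F)cc2)c1)C(=O)O` share one core and differ only in a fluoro in place of hydrogen on an aromatic carbon. In an assay on cells for agonist activity at probable G-protein coupled receptor 34 (Mus musculus), with a stated time of 1 h (a lower number here means a smaller maximal response, a higher number a larger maximal response), compound 1 gives 19.4% and compound 2 gives 18.7%; the step of a number 0.7 percentage points lower from compound 1 to compound 2 (within the scatter) lies within the scatter. Compound 2 thus holds the lowest of the two numbers, though its distance from compound 1 carries no order. Compound 3 `N[C@@H](COP(=O)(O)OCCCOC(=O)CCc1ccccc1OCc1cccc(Oc2ccc(I)cc2)c1)C(=O)O` carries the change (iodo in place of fluoro on an aromatic carbon). Within the data shown here, the only measured step at this position is the one from hydrogen to fluoro, which stayed within the scatter; no step from fluoro to iodo has been measured. On that basis no step beyond the scatter is expected in this assay, and the estimated step of a number 0.3 percentage points higher from compound 2 to compound 3 (within the scatter) is essentially flat. Compound 3 is therefore expected to give 19%, in a range from 9% to 31%.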

Compound 3, largest response reached (Emax), in percent of the reference or control that the assay uses: 19.1%
The estimate for compound 3 lay 0.1 percentage points below the measured number; low and high end bracket the measured number.
By their numbers in this assay, from the lowest: compounds 2, 3 and 1 (each within the scatter of the next).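

In this assay, iodo in place of fluoro gives a number 0.4 percentage points higher from compound 2 to compound 3 (within the scatter), and iodo in place of hydrogen gives a number 0.3 percentage points lower from compound 1 to compound 3 (within the scatter). Where the earlier pair covered fluoro alone, hydrogen, fluoro and iodo now cannot be told apart on this aromatic carbon, para to a large group, so the flat reading extends to a second halogen. No measurement available here bears on why the maximal response stays flat across these groups.

Still open, going by these compounds, is whether a group of another kind at this place, such as an amine, a carboxylic acid or a methoxy, would give a step beyond the scatter. Also open, on these data alone, is whether a longer chain elsewhere on the shared core would change the response.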